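Swapping the Five-Membered Ring on a Weak Antiproliferative Scaffold

The source may hold more compounds than are shown below. What is called first, only, known or untested is meant among the compounds shown, and "the series" means these compounds.

Three compounds share one core and differ only at the amide end. Compound 1 `Cc1noc(C)c1-c1nn(Cc2ccc(C(=O)NC3CCCCC3)cc2)c(=O)c2ccccc12` carries a cyclohexylamino group; in a functional assay on LoVo cells (Homo sapiens) for antiproliferative activity, read by MTT assay, with a stated time of 72 h (a lower number here means a stronger inhibitor, a higher number a weaker inhibitor), compound 1 gives 82200 nM. Compound 2 `Cc1noc(C)c1-c1nn(Cc2ccc(C(=O)N3CCCCC3)cc2)c(=O)c2ccccc12` carries a piperidin-1-yl group instead. In this assay compound 2 sits at a limit of the assay, > 100000 nM. Compound 3 `Cc1noc(C)c1-c1nn(Cc2ccc(C(=O)NC3CCCC3)cc2)c(=O)c2ccccc12` carries a cyclopentylamino group. In this assay compound 3 also sits at a limit of the assay, > 100000 nM. The step of an at least 1.2-fold higher number from compound 1 to compound 2 (0.08 log units; that floor lies within the scatter) and the step of an at least 1.2-fold higher number from compound 1 to compound 3 (0.08 log units; that floor lies within the scatter) are therefore only floors, and both fall within the usual scatter, while the step that the two limits leave unreadable from compound 2 to compound 3 cannot be read. Compound 2 thus stands at the weak edge of what was measured, and the limit of > 100000 nM in this assay, at which 2 of the 3 values shown sit, shows how little the assay separates these three.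

Compound 4 `Cn1cc(-c2nn(Cc3ccc(C(=O)N4CCCCC4)cc3)c(=O)c3ccccc23)cn1` keeps the piperidin-1-yl amide of compound 2 and changes the aromatic five-membered ring: 1-methyl-1H-pyrazol-4-yl in place of 3,5-dimethyl-1,2-oxazol-4-yl on an aromatic carbon. For the measured compounds named here, none of the measured steps touches this position; all of them change the amide end, so no measured step gives a direction for the ring swap. The estimated step that the limit leaves unreadable from compound 2 to compound 4 is expected to lie within the scatter. Compound 4 is therefore estimated at 120000 nM, with a range from 40000 nM to 300000 nM in this assay.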

Compound 4, half-maximal inhibitory concentration: 77100 nM
Beside the measured number, compound 4's estimate is 1.6-fold (0.19 log units) above it; the measured number falls inside the stated range.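

Until this point every step changed the amide end; here the piperidin-1-yl amide stays, 1-methyl-1H-pyrazol-4-yl replaces 3,5-dimethyl-1,2-oxazol-4-yl at the aromatic carbon, and the result is an at least 1.2-fold lower number from compound 2 to compound 4 (0.11 log units; that floor lies within the scatter). Both groups are a five-membered aromatic ring with 2 hetero atoms, and in this assay compound 4 gives 77100 nM, which is a number rather than a limit for a compound with this amide. No gain in strength can be claimed for the new ring, and the true size of the step stays hidden because it starts from a limit: the limit of > 100000 nM in this assay, at which 2 of the 4 values shown sit.

Going by these compounds, whether a six-membered ring such as phenyl or pyridin-4-yl at this position, or a longer chain such as ethyl in place of the methyl on the ring nitrogen, would move the number beyond the usual scatter remains open. On these data alone, it is equally open whether 1-methyl-1H-pyrazol-4-yl would give a readable number alongside the cyclohexylamino or cyclopentylamino amide, or alongside an amide end carrying an amine or a carboxylic acid.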